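This account rests on a few compounds, and the source may have more. Where it says the series, first, only, none or still open, it means among the compounds named here.

Compound 1 `COCCNC(=O)c1cc2cccc(OC)c2oc1=N` and compound 2 `CCC(CO)NC(=O)c1cc2cccc(OC)c2oc1=N` share one core and differ in a single place: 1-(hydroxymethyl)propyl in place of 2-methoxyethyl on an amide-type nitrogen. In an assay on HeLa cells for displacement of a labelled ligand from adenosine receptor A3 (Homo sapiens), read by scintillation counting, with a stated time of 180 min, tested at 10 uM (a lower number here means less inhibition, a higher number more inhibition at the concentration tested (going by the name of the read-out)), compound 1 gives 15%, and compound 2 gives 6%. The step of a number 9 percentage points lower from compound 1 to compound 2 (within the scatter) thus stays inside the usual scatter. Compound 3 `COCCNC(=O)c1cc2cc(Cl)ccc2oc1=N` carries another core; how its core differs from that of compound 1 is not broken down here. In this assay compound 3 gives 13%, a number close to those of compound 1 and compound 2 alike. Compound 4 `CCC(CO)NC(=O)c1cc2cc(Cl)ccc2oc1=N` is not yet measured. It differs from compound 3 by 1-(hydroxymethyl)propyl in place of 2-methoxyethyl on an amide-type nitrogen, the same change that separates compound 1 from compound 2, at the same place. The step of a number 7 percentage points lower from compound 3 to compound 4 (within the scatter) is expected to be small, because the step of a number 9 percentage points lower from compound 1 to compound 2 (within the scatter) was small. Compound 4 is therefore estimated at 6%, between -5% and 17%.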

Compound 4, a percentage reported as inhibition, at one concentration (the size of the read-out at that concentration, not a potency): 0%
The estimate for compound 4 lay 6 percentage points above the measured number; the range from low to high includes it.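

In this assay, the new step is a number 13 percentage points lower from compound 3 to compound 4 (beyond the scatter). Set beside the earlier step on the other core, it does not differ from it by more than the scatter allows: the same change on two cores in this assay, a number 9 percentage points lower (within the scatter) from compound 1 to compound 2 and a number 13 percentage points lower (beyond the scatter) from compound 3 to compound 4, 4 percentage points apart, within the scatter of two such steps The change of 2-methoxyethyl to 1-(hydroxymethyl)propyl thus carried over between these two cores, but two pairs read at a single concentration show nothing about potency or about any further core.

The compounds shown leave open how a longer alkyl chain, or a chain ending in an amine or a carboxylic acid, would read on the same amide-type nitrogen. They also leave open whether either chain would behave the same way with other groups on the core.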